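A few compounds are considered here, and "the series" means these few. Any claim that something is new, unique, unknown or untested is made for them only; others in the source may bear on it.

Measured compounds:
- compound 1, `Cc1c(OCCCCOc2ccc(C(=O)CC(C)(C)C)c(O)c2C)cccc1C(=O)O`: 300 nM
- compound 2, `Cc1c(OCCCCOc2ccc(C(=O)C(C)C)c(O)c2C)cccc1C(=O)O`: "not determined" (no result reported)

Among the compounds with values here, in an assay on HEK293 cells for positive allosteric modulation of metabotropic glutamate receptor 3 (Rattus norvegicus), read by thallium flux, with a stated time of 2.5 min (a lower number here means that less compound is needed, a higher number that more compound is needed for the effect), compound 1 gives 300 nM, the only number available here, so nothing can be ranked against it. Compound 3, `Cc1c(OCCCCOc2ccc(F)c(C(=O)O)c2)ccc(C(=O)CC(C)(C)C)c1O`, is not yet measured; it differs from compound 1 by 3-carboxy-4-fluorophenyl in place of 3-carboxy-2-methylphenyl on an oxygen on a saturated carbon. No measured pair shows what such a swap does, so the step is expected to be modest, with a slight loss more likely than a gain, as shown by a 1.7-fold higher number from compound 1 to compound 3 (0.22 log units; within the scatter). Compound 3 is therefore estimated at 500 nM, within a range from 150 nM to 2000 nM.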

Compound 3, half-maximal effective concentration: 258 nM
Estimate against measurement, compound 3: 1.9-fold (0.29 log units) above; the range from low to high includes it.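

In this assay the first measured pair, 3-carboxy-4-fluorophenyl in place of 3-carboxy-2-methylphenyl, gives a 1.2-fold lower number from compound 1 to compound 3 (0.07 log units; within the scatter) and leaves the two compounds indistinguishable. This position on the oxygen therefore tolerates this exchange of ring groups without a measurable difference. Nothing measured here explains this result.

The pair cannot separate the loss of the methyl from the gain of the fluorine, since both occur in one step. The compounds shown also leave open what an amine in place of the carboxylic acid would do.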